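Ethyl for Methoxy on the Aromatic Ring of Compound 2

The source may hold more compounds than are shown below. What is called first, only, known or untested is meant among the compounds shown, and "the series" means these compounds.

Three compounds have been measured in a functional assay on BGC-823 cells (Homo sapiens) for cytotoxicity, read by MTT assay, with a stated time of 72 h; a lower number here means a stronger inhibitor, a higher number a weaker inhibitor:
Compound 1 `CN1[C@@H]2c3[nH]c4ccccc4c3C[C@H]1[C@H](C#N)N1[C@@H](CN3C(=O)c4ccccc4C3=O)c3[nH]c4ccccc4c3C[C@@H]21` gives 410 nM.
Compound 2 `COc1ccc(C(=O)NC[C@H]2c3[nH]c4ccccc4c3C[C@H]3[C@H]4c5[nH]c6ccccc6c5C[C@@H]([C@H](C#N)N23)N4C)cc1` gives 320 nM.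
Compound 3 `CN1[C@@H]2c3[nH]c4ccccc4c3C[C@H]1[C@H](C#N)N1[C@@H](CNC(=O)c3ccc(F)cc3)c3[nH]c4ccccc4c3C[C@@H]21` gives 310 nM.

Compound 2 sits between its two neighbours, and both steps to them, a 1.3-fold lower number from compound 1 to compound 2 (0.11 log units; within the scatter) and a 1.0-fold lower number from compound 2 to compound 3 (0.01 log units; within the scatter), fall inside the scatter, so no order among the three can be read. Compound 4 `CCc1ccc(C(=O)NC[C@H]2c3[nH]c4ccccc4c3C[C@H]3[C@H]4c5[nH]c6ccccc6c5C[C@@H]([C@H](C#N)N23)N4C)cc1` differs from compound 2 by ethyl in place of methoxy on an aromatic carbon. Among the compounds with values here, the one step that bears on this, the swap of fluoro for methoxy at the same aromatic carbon, gave a 1.0-fold lower number from compound 2 to compound 3 (0.01 log units; within the scatter), and the larger exchanges a 1.3-fold lower number from compound 1 to compound 2 (0.11 log units; within the scatter) and a 1.3-fold lower number from compound 1 to compound 3 (0.12 log units; within the scatter) were likewise within scatter. Compound 4 is therefore expected to show a 1.1-fold higher number from compound 2 to compound 4 (0.03 log units; within the scatter), a step not beyond the scatter. The estimate for compound 4 is 340 nM, with a range from 170 nM to 680 nM.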

Compound 4, half-maximal inhibitory concentration: 660 nM
Compound 4: middle estimate off by 1.9-fold (0.29 log units), on the low side; measured number inside the range.
By their numbers in this assay, from the lowest: compounds 3, 2, 1 and 4 (each within the scatter of the next, the first and the last beyond it).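

In this assay the group on this aromatic carbon now makes a measurable difference: the change to ethyl gives a 2.1-fold higher number from compound 2 to compound 4 (0.31 log units; beyond the scatter) and also a 2.1-fold higher number from compound 3 to compound 4 (0.33 log units; beyond the scatter) and both steps are modest, whereas methoxy and fluoro had remained within the scatter of each other. The wider exchange of the whole side group gives a 1.6-fold higher number from compound 1 to compound 4 (0.21 log units; within the scatter) and so cannot be read as a change. Nothing available here explains the ethyl result.

The compounds shown leave open whether this step is particular to ethyl or continues with a longer chain. A propyl chain or an amine on the same aromatic carbon would address that.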